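The compounds below may be only part of what the source reports. "The series", "measured", "known", "first", "only" and "open" are said of these compounds alone.

Working notes on the series. Among the measured compounds shown here, compound 1 `COc1ccc(CNc2nc3cc(N)cc(N)c3nc2-c2ccccc2)cc1OC` stands highest of the two numbers so far: in a functional assay on NCI-H226 cells (Homo sapiens) for inhibition, read by sulforhodamine B assay, with a stated time of 48 h (on this read-out lower numbers stand for stronger inhibition of growth and higher numbers for weaker inhibition of growth), compound 1 gives 30900 nM, while compound 2 `COc1cc(CNc2nc3cc(N)cc(N)c3nc2-c2ccccc2)cc(OC)c1OC` gives 22400 nM. For the measured compounds named here, the only step in hand, a 1.4-fold lower number from compound 1 to compound 2 (0.14 log units; within the scatter), adds a methoxy and stays within the scatter. Compound 3 `COc1ccc(CNc2nc3cc(N)cc(N)c3nc2-c2ccccc2)cc1` goes the other way from compound 1: hydrogen in place of methoxy on an aromatic carbon. Nothing measured shows a methoxy count on this ring moving the number beyond the scatter, so for compound 3 the expected step of a 1.0-fold lower number from compound 1 to compound 3 (0.01 log units; within the scatter) is none beyond the scatter. Compound 3 is therefore estimated at 30000 nM, in the range 12000 nM to 75000 nM.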

Compound 3, concentration for total growth inhibition: 70800 nM
Compound 3: the middle estimate sits 2.4-fold (0.37 log units) below what was measured; the measured number falls inside the stated range.
By their numbers in this assay, from the lowest: compounds 2 and 1 (each within the scatter of the next); then compound 3.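

Hydrogen in place of the methoxy that sits ortho to a methoxy group and meta to a large group (3,4-dimethoxyphenyl to 4-methoxyphenyl) gives a 2.3-fold higher number from compound 1 to compound 3 (0.36 log units; beyond the scatter) in this assay, a modest step and the only one beyond the scatter. This methoxy therefore counts for something here, unlike the methoxy added in a 1.4-fold lower number from compound 1 to compound 2 (0.14 log units; within the scatter). Nothing at hand accounts for the difference.

As far as these compounds go, whether the step belongs to this position or to the methoxy count on the ring stays open. Also open, from the compounds shown here alone, is whether a hydroxy, an ethoxy or a fluorine in this place would keep the number of compound 1.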